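Hydrogen for chloro on the aromatic ring of compound 1

This account rests on a few compounds, and the source may have more. Where it says the series, first, only, none or still open, it means among the compounds named here.

compound 1, `[O-][S+](CCC(F)(Cl)C(F)(F)Cl)c1nc2ccc(Cl)cc2s1`: a functional assay on SH-SY5Y cells (Homo sapiens) for cytotoxicity, read by MTT assay, with a stated time of 48 h (a lower number here means a stronger inhibitor, a higher number a weaker inhibitor), 2100 nM
compound 2, `N#CC(C#N)(CCC(F)=C(F)F)Cc1nccs1`: a limit, > 120000 nM

Within the data shown here, compound 1 gives the only number in this assay; the value of compound 2 is a limit and not a number, which is the limit of > 120000 nM in this assay, at which 1 of the 2 values shown sits. Among the measured compounds shown here, the two compounds share no single-point change, so no measured step exists between them, and compound 1 stands alone as the reference for the change considered here.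

Compound 3, `[O-][S+](CCC(F)(Cl)C(F)(F)Cl)c1nc2ccccc2s1`, keeps the shared core and the side chain of compound 1 and differs only in hydrogen in place of chloro on an aromatic carbon. For the measured compounds named here, since no measured step in the set reports what removal of a ring chloro does in this assay, the expectation rests on the size of the change alone: one heavy atom leaves and nothing beyond hydrogen enters.

For compound 3 the step of a 1.9-fold higher number from compound 1 to compound 3 (0.28 log units; within the scatter) is expected to be small, towards weaker inhibition, and possibly within the scatter. Compound 3 is estimated at 4000 nM in this assay, with a range from 1500 nM to 12000 nM.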

Compound 3, half-maximal inhibitory concentration: 41500 nM
Beside the measured number, compound 3's estimate is 10-fold (1.02 log units) below it; the whole stated range lies below it.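

In this assay, among these compounds, the hydrogen-for-chloro change gives a 20-fold higher number from compound 1 to compound 3 (1.30 log units; beyond the scatter), the first measured step at this position, and it is a large one. The change itself is minimal: one chlorine atom leaves a carbon of the six-membered aromatic ring, no ring is lost, no hydrogen-bond donor or acceptor is involved and no net charge is altered, yet the step lies beyond the scatter, so within this pair the count of atoms exchanged says little about the size of the step. The values shown offer no measured property that accounts for this step, and the limit of compound 2 has no bearing on it, since compound 2 shares no single-point change with either compound:.

On these data alone, only chloro and hydrogen appear at this ring carbon, so it remains open where a fluoro, a methyl, a methoxy or an amine at the same place would fall relative to compound 1 and compound 3. As far as these compounds go, it also remains open whether the step keeps its size when the chlorofluoroalkyl side chain of compound 1 gives way to a shorter or longer chain on the shared core.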